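Swapping hydroxy for ethyl: what compound 3 may give

The source may report more compounds than this note shows. Statements on the series, on what has been measured and on what is new or still open speak of the compounds shown alone.

Of the compounds shown here, two have been measured in an assay on isolated protein for binding affinity to adenosine receptor A1 (Bos taurus); on this read-out lower numbers stand for stronger inhibition and higher numbers for weaker inhibition. Compound 1 `CCCCNc1nc(-c2ccccc2)nc2c1nnn2Cc1ccccc1C(F)(F)F` gives 6500000 nM. Compound 2 `OCCNc1nc(-c2ccccc2)nc2c1nnn2Cc1ccccc1` gives 38000000 nM, the higher of the two numbers; its nearest neighbour is compound 1, whose number is lower by an amount beyond the usual scatter.

Compound 3 `CCCCNc1nc(-c2ccccc2)nc2c1nnn2Cc1ccccc1` has not yet been measured. It differs from compound 2 in one place: ethyl in place of hydroxy on a saturated chain carbon, two bonds along the chain from a nitrogen on an aromatic ring, so that the (2-hydroxyethyl)amino group of compound 2 becomes the butylamino group in compound 3.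

Among the measured compounds shown here, no step between measured compounds matches this change, so its size cannot be read off directly. For the measured compounds named here, the only guide is that compound 2 stands at the top of the two numbers in this assay and that compound 1 gives 6500000 nM, so a step to a lower number for compound 3 seems more likely than a step upward, with a good chance it stays within the scatter. The estimate for compound 3 is therefore 12000000 nM, with a range from 3000000 nM to 45000000 nM, and the expected step of a 3.2-fold lower number from compound 2 to compound 3 (0.50 log units; beyond the scatter) is modest.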

Compound 3, inhibition constant: 11000000 nM
Compound 3: middle estimate off by 1.1-fold (0.04 log units), on the high side; low and high end bracket the measured number.
By their numbers in this assay, from the lowest: compounds 1 and 3 (each within the scatter of the next); then compound 2.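

In this assay, among the compounds shown here, the first step that can be read at this position is a 3.5-fold lower number from compound 2 to compound 3 (0.54 log units; beyond the scatter) when ethyl takes the place of hydroxy on the saturated chain carbon, so the butylamino group gives a lower number than the (2-hydroxyethyl)amino group on the same core. Hydrogen in place of trifluoromethyl on an aromatic carbon gives a 1.7-fold higher number from compound 1 to compound 3 (0.23 log units; within the scatter) and so cannot be told apart from repeat measurements of this kind. Compound 3 thus gives both earlier compounds a neighbour that differs in one place, and only the change on the chain separates from the scatter. Nothing given here explains the size of either step.

The step from compound 2 to compound 3 removes hydroxy and lengthens the chain together, so a propyl chain, a methoxy group or an amine on the same chain would be needed to tell these apart. Going by these compounds, it also remains open whether trifluoromethyl would leave the number as little changed alongside the (2-hydroxyethyl)amino group, and what a chlorine or a nitrile on that aromatic carbon would do.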